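Methoxy to Trifluoromethyl: Expecting the Number for Compound 4

This account rests on a few compounds, and the source may have more. Where it says the series, first, only, none or still open, it means among the compounds named here.

Compound 1 `CCCCc1ccc2[nH]c(-c3ccc(OC)cc3)c(/C=N/NC(=O)c3ccc(Cl)cc3)c2c1` serves as the reference. In a functional assay on MCF7 cells (Homo sapiens) for antiproliferative activity, with a stated time of 5 days (a higher number here means a weaker inhibitor, a lower number a stronger inhibitor), compound 1 gives 220 nM. Compound 2 `CCCCc1ccc2[nH]c(-c3ccc(C(F)(F)F)cc3)c(/C=N/NC(=O)c3ccc(Cl)cc3)c2c1` carries trifluoromethyl in place of methoxy on an aromatic carbon; in this assay compound 2 gives 1060 nM, which is a 4.8-fold higher number from compound 1 to compound 2 (0.68 log units; beyond the scatter). Compound 3 `CCCCc1ccc2[nH]c(-c3ccc(OC)cc3)c(/C=N/NC(=O)c3ccncc3)c2c1` differs from compound 1 by pyridin-4-yl in place of 4-chlorophenyl on a carbonyl carbon; in this assay compound 3 gives 69 nM, which is a 3.2-fold lower number from compound 1 to compound 3 (0.50 log units; beyond the scatter), the lowest number of the three. Compound 4 `CCCCc1ccc2[nH]c(-c3ccc(C(F)(F)F)cc3)c(/C=N/NC(=O)c3ccncc3)c2c1` has not yet been measured. It differs from compound 3 by trifluoromethyl in place of methoxy on an aromatic carbon, the same change as that from compound 1 to compound 2, now made on the core of compound 3 rather than that of compound 1. Because the same change gave a 4.8-fold higher number from compound 1 to compound 2 (0.68 log units; beyond the scatter), compound 4 is expected to show a step of similar size, a 4.8-fold higher number from compound 3 to compound 4 (0.68 log units; beyond the scatter). Compound 4 is therefore estimated at 330 nM in this assay, with a range from 120 nM to 900 nM, an expectation resting on a single earlier example.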

Compound 4, half-maximal inhibitory concentration: 100 nM
Beside the measured number, compound 4's estimate is 3.3-fold (0.52 log units) above it, and the stated range ends above it.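

With the pyridin-4-yl group in place, trifluoromethyl for methoxy gives a 1.4-fold higher number from compound 3 to compound 4 (0.16 log units; within the scatter) in this assay, so the step seen with 4-chlorophenyl did not carry over at its earlier size: the same change on two cores in this assay, a 4.8-fold higher number (0.68 log units; beyond the scatter) from compound 1 to compound 2 and a 1.4-fold higher number (0.16 log units; within the scatter) from compound 3 to compound 4, 3.3-fold (0.52 log units) apart, beyond the scatter of two such steps

Read the other way, pyridin-4-yl in place of 4-chlorophenyl gives an 11-fold lower number from compound 2 to compound 4 (1.03 log units; beyond the scatter), and this step also differs from its earlier counterpart: the same change on two cores in this assay, a 3.2-fold lower number (0.50 log units; beyond the scatter) from compound 1 to compound 3 and an 11-fold lower number (1.03 log units; beyond the scatter) from compound 2 to compound 4, 3.3-fold (0.52 log units) apart, beyond the scatter of two such steps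

In these four compounds, the size of each step thus depends on the group at the other place, but this single square of compounds does not show why, or whether the same holds elsewhere in the series.

The compounds shown leave open how an amine or a chlorine in place of the methoxy would behave with each of the two carbonyl substituents. They also leave open whether a shorter chain than butyl would change these steps.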